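Swapping a methoxy for a methoxycarbonyl on compound 2

A few compounds are considered here, and "the series" means these few. Any claim that something is new, unique, unknown or untested is made for them only; others in the source may bear on it.

Of the compounds shown here, three have been tested so far in an ADME assay on PBMC cells (Homo sapiens) for cytotoxicity; on this read-out lower numbers stand for higher toxicity in this test and higher numbers for lower toxicity in this test. Compound 1 `CCO/N=C(/c1ccc(Br)cc1)C1CCN(C(C)(C)CCNC(=O)c2c(Cl)cncc2Cl)CC1` gives 34000 nM, compound 2 `COc1cccc(OC(c2ccc(C(F)(F)F)cc2)C2CCN(C(C)CCNC(=O)c3c(Cl)cncc3Cl)CC2)n1` gives 32700 nM, and compound 3 `CC(CCNC(=O)c1c(Cl)cncc1Cl)N1CCC(C(Oc2cccnc2)c2ccc(Br)cc2)CC1` gives 32500 nM. These three numbers cannot be told apart: compound 2 sits among values that all lie within the usual scatter of one another, so none of the three can be called more or less toxic than the others in this assay.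

Compound 4 `COC(=O)c1cccc(OC(c2ccc(C(F)(F)F)cc2)C2CCN(C(C)CCNC(=O)c3c(Cl)cncc3Cl)CC2)n1` has not yet been measured. It differs from compound 2 in one place: methoxycarbonyl in place of methoxy on an aromatic carbon. Among the measured compounds shown here, no pair of measured compounds shows what this particular change does. The three measured compounds, despite differing from one another in several places, all land at nearly the same number, which suggests this series is not very sensitive to such changes in this assay.

For that reason no step beyond the scatter is expected, and the estimated step of a 1.0-fold higher number from compound 2 to compound 4 (0.00 log units; within the scatter) is small. Compound 4 is expected to give about 33000 nM, with a likely range from 16000 nM to 68000 nM.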

Compound 4, half-maximal cytotoxic concentration: 14600 nM
For compound 4 the middle estimate is 2.3-fold (0.35 log units) above the measured one; measured number below the stated range.
By their numbers in this assay, from the lowest: compound 4; then compounds 3, 2 and 1 (each within the scatter of the next).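

Replacing methoxy with methoxycarbonyl on an aromatic carbon next to the ring nitrogen gives a 2.2-fold lower number from compound 2 to compound 4 (0.35 log units; beyond the scatter) in this assay. Among the compounds shown here, this is the first change in a single place seen in this set, and it shows that this position is not silent: altering this one group is enough to move the number beyond the scatter, though only modestly, and towards higher toxicity in this test. No measurement available here accounts for the shift.

Going by these compounds, it remains open whether the shift belongs to the methoxycarbonyl group specifically or would also appear with other groups on the same carbon, such as a carboxylic acid, a primary amide or a nitrile. Also unresolved is whether the same swap would have a similar effect in compounds with a different side chain or a different aryl group.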